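Chromone acrylamides: swapping a benzyl amide for an anilide

This account rests on a few compounds, and the source may have more. Where it says the series, first, only, none or still open, it means among the compounds named here.

Compound 1 `O=C(/C=C/c1coc2cc(O)ccc2c1=O)NCc1ccccc1` gives > 100000 nM in a functional assay on A549 cells (Homo sapiens) for inhibition, read by MTT assay, with a stated time of 48 h (on this read-out higher numbers stand for weaker inhibition and lower numbers for stronger inhibition), a limit of the assay rather than a number.
Compound 2 `COc1ccc2c(=O)c(/C=C/C(=O)NCc3ccccc3)coc2c1` gives 11800 nM in this assay.
Compound 3 `COc1ccc2c(=O)c(/C=C/C(=O)NCc3ccc(F)cc3)coc2c1` gives > 100000 nM in this assay, again a limit and not a number.

Compound 1 therefore stands at the limit of this assay; it shares that position with compound 3 (the limit of > 100000 nM in this assay, at which 2 of the 3 values shown sit). Compound 4 `Cc1ccccc1NC(=O)/C=C/c1coc2cc(O)ccc2c1=O` differs from compound 1 by 2-methylphenyl in place of benzyl on an amide-type nitrogen. Neither measured step touches the amide substituent: an at least 8.4-fold lower number from compound 1 to compound 2 (0.92 log units; beyond the scatter) concerns the phenol, and an at least 8.4-fold higher number from compound 2 to compound 3 (0.92 log units; beyond the scatter) concerns the ring of the benzyl group. Within the data shown here, no measured step therefore bears on this change, and no shift beyond the scatter is expected. For compound 4 the estimated value is 100000 nM, with a range of 25000 nM to 400000 nM. The expected step is a number no higher from compound 1 to compound 4 (the limit leaves the size open).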

Compound 4, half-maximal inhibitory concentration: > 100000 nM
Compound 4 gave a limit, no number; the forecaster's own chance of this, stated with the estimate: 70%; the middle value lies on the limit itself.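

Among these compounds, compound 1 and compound 4 both stand as limits in this assay, not as numbers, so no step between them can be read: the limit of > 100000 nM in this assay, at which 3 of the 4 values shown sit.

The compounds shown leave open whether 2-methylphenyl in place of benzyl on the amide-type nitrogen changes inhibition at all.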